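The compounds below may be only part of what the source reports. "The series", "measured", "known", "first", "only" and "open" are said of these compounds alone.

Working notes on the series. Three analogues have been run so far in a functional assay on SNB-19 cells (Homo sapiens) for cytotoxicity, read by sulforhodamine B assay, with a stated time of 48 h, tested at 100 uM; a lower number here means a stronger effect, a higher number a weaker effect of the compound at the concentration tested: compound 1 `COc1cc(-c2cc(/C=C/C(=O)c3ccc(N)cc3)[nH]n2)cc(OC)c1OC`, compound 2 `COc1ccc(-c2cc(/C=C/C(=O)c3ccc(OC)c(OC)c3)[nH]n2)cc1` and compound 3 `COc1ccc(-c2cc(/C=C/C(=O)c3cc(OC)c(OC)c(OC)c3)[nH]n2)cc1OC`. In this assay compound 1 gives -94%, compound 2 gives -96% and compound 3 gives -77%. Among these three numbers compound 1 stands second highest; its nearest neighbour is compound 2, whose value lies within the scatter of that of compound 1, while compound 3 lies furthest away, with a gap beyond the scatter. Compounds 1 and 2 therefore cannot be ordered against each other; compound 3 alone is set apart.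

The next compound, compound 4 `COc1ccc(C(=O)/C=C/c2cc(-c3cc(OC)c(OC)c(OC)c3)n[nH]2)cc1OC`, has not yet been run in this assay. Against compound 1 the difference is 3,4-dimethoxyphenyl in place of 4-aminophenyl on a carbonyl carbon. Going by the values given here, no step between two measured compounds has been recorded for this change, so no size can be read off directly. Compound 2 carries the 3,4-dimethoxyphenyl on its carbonyl carbon and gives a value within the scatter of compound 1, so for compound 4 the step from compound 1 is expected to be small, a number 4 percentage points higher from compound 1 to compound 4 (within the scatter), not beyond the scatter in either direction. Compound 4 is accordingly expected to come out near -90% in this assay, with a range from -99% to -72%.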

Compound 4, a percentage reported as activity, at one concentration (the size of the read-out at that concentration, not a potency): -95%
Compound 4: the middle estimate sits 5 percentage points above what was measured; measured number inside the range.
By their numbers in this assay, from the lowest: compounds 2, 4 and 1 (each within the scatter of the next); then compound 3.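

Going by these compounds alone, the step of a number 1 percentage points lower from compound 1 to compound 4 (within the scatter) is the first one recorded on a carbonyl carbon, and it gives a direct reading for 3,4-dimethoxyphenyl in place of 4-aminophenyl in this assay. The two groups differ in heavy atoms, hydrogen-bond donors and hydrogen-bond acceptors, yet with the rest of the structure held constant, this exchange produces no difference that can be separated from the scatter. No measurement available here explains this result or links it to any feature of either group.

The read-out comes from one concentration and is not a potency, so the two compounds may still differ at lower concentrations, and this single exchange does not show how far the position tolerates other groups. From the compounds shown here alone, whether a phenyl ring carrying a carboxylic acid, or a simple alkyl chain with no aromatic ring, would keep the read-out on this carbonyl carbon remains open.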